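Methoxy to hydroxy on compound 1: working notes

The compounds below may be only part of what the source reports. "The series", "measured", "known", "first", "only" and "open" are said of these compounds alone.

In a physicochemical assay for lipophilicity (a lower number here means a more polar compound, a higher number a more lipophilic compound), compound 1 `COc1ccc(C2=N[C@@H](C(=O)O)CS2)c(O)c1` gives -0.89, the higher of the two readings so far, and compound 2 `O=C(O)[C@H]1CSC(c2cc(O)ccc2O)=N1` gives -1.52, lower by more than the scatter. Compound 3 `O=C(O)[C@H]1CSC(c2ccc(O)cc2O)=N1` differs from compound 1 by hydrogen in place of methyl on an oxygen on an aromatic ring, or methoxy to hydroxy. Within the data shown here, no measured pair isolates this change, so the value of compound 2, -1.52, serves as the only guide. The expected step, a number 0.46 log units lower from compound 1 to compound 3 (beyond the scatter), is downward and beyond the scatter. For compound 3 the estimated value in this assay is -1.35, with an expected range from -1.7 to -1.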

Compound 3, partition coefficient: -1.33
The estimate for compound 3 lay 0.02 log units below the measured number, and the stated range covers the measured number.
By their numbers in this assay, from the lowest: compounds 2 and 3 (each within the scatter of the next); then compound 1.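

In this assay, among these compounds, methoxy to hydroxy now has a directly measured size, a number 0.44 log units lower from compound 1 to compound 3 (beyond the scatter), the first step that isolates a single change. It gives the exchange of methyl for hydrogen on an oxygen on an aromatic ring a modest downward reading on the core of compound 1, but a single pair establishes no pattern. No available measurement accounts for the size of this step.

Still open, on these data alone, is how an ethoxy group or an amine at this place would read. Whether the step carries over to other members of the series also remains unsettled.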